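Replacing trifluoromethyl with dimethylamino on the shared core

The source may hold more compounds than are shown below. What is called first, only, known or untested is meant among the compounds shown, and "the series" means these compounds.

Three compounds have been measured in an assay on LM cells for displacement of a labelled ligand from Neuropeptide Y receptor type 5 (Homo sapiens); on this read-out higher numbers stand for weaker inhibition and lower numbers for stronger inhibition:
Compound 1 `Fc1ccc(C2(c3ccc(F)cc3)CNC(c3cccc(C(F)(F)F)c3)=N2)cc1`: 6.2 nM
Compound 2 `O=Cc1cccc(C2=NC(c3ccc(F)cc3)(c3ccc(F)cc3)CN2)c1`: 8.7 nM
Compound 3 `Nc1cccc(C2=NC(c3ccc(F)cc3)(c3ccc(F)cc3)CN2)c1`: 300 nM

Compound 1 gives the lowest number of the three. Compound 2, in which formyl replaces trifluoromethyl, lies within the scatter of it: a 1.4-fold higher number from compound 1 to compound 2 (0.15 log units; within the scatter). Compound 3, in which amino replaces the same group, is far weaker: a 48-fold higher number from compound 1 to compound 3 (1.68 log units; beyond the scatter), and against compound 2 the same holds, a 34-fold higher number from compound 2 to compound 3 (1.54 log units; beyond the scatter).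

Compound 4 `CN(C)c1cccc(C2=NC(c3ccc(F)cc3)(c3ccc(F)cc3)CN2)c1` has not yet been measured. It differs from compound 1 in one place: dimethylamino in place of trifluoromethyl on an aromatic carbon.

Among the compounds with values here, the step that bears most on this change is the one from compound 1 to compound 3, where a nitrogen-linked group took the place of trifluoromethyl and cost a large amount of potency. Dimethylamino carries no hydrogen-bond donor, unlike amino, so the full size of that loss need not recur, but the result of compound 2 shows that a change at this carbon can also be without effect. Compound 4 is therefore expected to give a higher number than compound 1, with a step of a 9.7-fold higher number from compound 1 to compound 4 (0.99 log units; beyond the scatter), but smaller than the loss seen for compound 3. The estimate for compound 4 is 60 nM, within a range of 12 nM to 300 nM.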

Compound 4, half-maximal inhibitory concentration: > 1000 nM
Compound 4 was reported as a limit (the forecaster's own chance of this, stated with the estimate: 3%); at least 16-fold (1.22 log units) between middle value and limit.
By their numbers in this assay, from the lowest: compounds 1 and 2 (each within the scatter of the next); then compound 3. At a limit, above all of these: compound 4.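

In this assay compound 4 is reported only as a limit, not as a number: the limit of > 1000 nM in this assay, at which 1 of the 4 values shown sits. Even so, the step from amino to dimethylamino can be read, and it brings no recovery, with an at least 3.3-fold higher number from compound 3 to compound 4 (0.52 log units; beyond the scatter), so the loss seen with amino at this aromatic carbon is not undone by dimethylamino, which goes further in the same direction. Against the two compounds that keep the low numbers, the drop is larger still, with an at least 160-fold higher number from compound 1 to compound 4 (2.20 log units; beyond the scatter) and an at least 110-fold higher number from compound 2 to compound 4 (2.06 log units; beyond the scatter), so that among the four groups shown at this carbon, trifluoromethyl and formyl go with the low numbers while both nitrogen-linked groups go with far higher ones.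

On these data alone, how far compound 4 lies beyond its limit stays open, and with it the true size of all three steps. Also open is whether the nitrogen attached directly to the ring goes with the loss in general, since the compounds shown do not tell how an acetamide, with its nitrogen bearing a carbonyl, or a methoxy group or a nitrile would fare at this carbon.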